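Chain lengthening in two linker variants: working notes

The source may hold more compounds than are shown below. What is called first, only, known or untested is meant among the compounds shown, and "the series" means these compounds.

Compound 1 `CCCCCCCCOc1cc(-c2ccccc2)c(-c2ccccc2)nn1` and compound 2 `CCCCCCCCCOc1cc(-c2ccccc2)c(-c2ccccc2)nn1` share a core and differ only at the far end of the chain. In an assay on microsomes from liver for inhibition of sterol O-acyltransferase 1 (Rattus norvegicus) (a lower number here means a stronger inhibitor, a higher number a weaker inhibitor), compound 1 gives 104000 nM, and compound 2 gives 180000 nM. The change between them is methyl in place of hydrogen on a saturated chain carbon, eight bonds along the chain from an oxygen on an aromatic ring, and the step it made is a 1.7-fold higher number from compound 1 to compound 2 (0.24 log units; within the scatter), so the two numbers cannot be told apart.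

Compound 3 `CCCCCCCCS(=O)(=O)c1cc(-c2ccccc2)c(-c2ccccc2)nn1` carries a different link between the chain and the core; the difference between the two cores is not broken down here. In this assay compound 3 gives 36000 nM, the lowest of the three numbers, with compound 1 beyond the scatter above it and compound 2 further still.

Compound 4 `CCCCCCCCCS(=O)(=O)c1cc(-c2ccccc2)c(-c2ccccc2)nn1` is not yet measured. It differs from compound 3 by methyl in place of hydrogen on a saturated chain carbon, eight bonds along the chain from a sulfonyl sulfur. Around the place, the chain carbon sits eight bonds from a sulfonyl sulfur rather than from an oxygen on an aromatic ring, so this is the same kind of change as that between compound 1 and compound 2, not the same change. For the measured compounds named here, the step from compound 3 to compound 4 in this assay is expected to be a 1.5-fold higher number from compound 3 to compound 4 (0.18 log units; within the scatter), because the only measured instance of this kind of change is a 1.7-fold higher number from compound 1 to compound 2 (0.24 log units; within the scatter) and the linker differs. Compound 4 is therefore estimated at 55000 nM in this assay, with a range from 18000 nM to 160000 nM.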

Compound 4, half-maximal inhibitory concentration: 76000 nM
The estimate for compound 4 lay 1.4-fold (0.14 log units) below the measured number, within the range that was stated.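

In this assay, methyl in place of hydrogen on a saturated chain carbon, eight bonds along the chain from a sulfonyl sulfur, gives a 2.1-fold higher number from compound 3 to compound 4 (0.32 log units; beyond the scatter), and this step does not differ from the one seen for the same change on the other core: the same change on two cores in this assay, a 1.7-fold higher number (0.24 log units; within the scatter) from compound 1 to compound 2 and a 2.1-fold higher number (0.32 log units; beyond the scatter) from compound 3 to compound 4, 1.2-fold (0.09 log units) apart, within the scatter of two such steps. The change therefore carries from the core of compound 1 to the core of compound 3 with no difference that this assay can resolve, even though only the newer step lies beyond the scatter on its own. This is a single pair of steps at one place on the chain, so it does not establish a rule for other chain lengths or other cores, and it does not explain the size of either step.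

The compounds shown leave open whether a longer chain would continue the same trend on either core, and whether the step would hold if the linking oxygen or sulfonyl were replaced by a thioether or an amide. They also leave open how either core would respond to a chain ending in an amine or a carboxylic acid.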